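The compounds below may be only part of what the source reports. "The series", "measured", "known", "first", "only" and "open" are said of these compounds alone.

In a functional assay on HepG2 cells (Homo sapiens), read by MTT assay, with a stated time of 48 h (a higher number here means a weaker inhibitor, a lower number a stronger inhibitor), compound 3 `CCN(CC)CCNC(=O)c1ccc(C(CC)(CC)c2ccc(OCC(O)C(C)(C)C)c(C)c2)n1CC` gives 490 nM, the lowest of the two actual numbers in this small set. Compound 1 `CCn1c(C(=O)NCCN(C)C)ccc1C(CC)(CC)c1ccc(OCC(=O)C(C)(C)C)c(C)c1` comes nearest with a higher 2300 nM, a gap beyond the scatter. Compound 2 `CCOC(=O)CN(C)C(=O)c1ccc(C(CC)(CC)c2ccc(OCC(O)C(C)(C)C)c(C)c2)n1CC` reaches only a limit, > 50000 nM.

The next compound, compound 4 `CCn1c(C(=O)NCCN(C)C)ccc1C(CC)(CC)c1ccc(OCC(O)C(C)(C)C)c(C)c1`, carries dimethylamino in place of diethylamino on a saturated chain carbon, two bonds along the chain from an amide-type nitrogen.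

For the measured compounds named here, only one measured step touches this part of the molecule. It is large, an at least 100-fold lower number from compound 2 to compound 3 (2.00 log units; beyond the scatter), and it shows that this assay can respond strongly to the group on this carbonyl carbon. That step replaces ((ethoxycarbonyl)methyl)(methyl)amino, however, so it does not give the size of the smaller change from diethylamino to dimethylamino. Compound 1 also bears 2-(dimethylamino)ethyl, and its 2300 nM offers a loose upper guide. A step far smaller than the large one is therefore expected, towards a moderately higher number, and it may stay close to the scatter. The expected change is a 1.6-fold higher number from compound 3 to compound 4 (0.21 log units; within the scatter). Compound 4 is estimated at 800 nM, with an expected range from 250 nM to 3000 nM.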

Compound 4, half-maximal inhibitory concentration: 870 nM
For compound 4 the middle estimate is 1.1-fold (0.04 log units) below the measured one, within the range that was stated.
By their numbers in this assay, from the lowest: compounds 3 and 4 (each within the scatter of the next); then compound 1. At a limit, above all of these: compound 2.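

In this assay, for the compounds shown here, the change from diethylamino to dimethylamino on a saturated chain carbon, two bonds along the chain from an amide-type nitrogen, amounts to a 1.8-fold higher number from compound 3 to compound 4 (0.25 log units; within the scatter), so this assay does not separate these two amines, which the earlier compounds could not show. Going by these compounds alone, the large step seen before also holds with the smaller amine, as (2-(dimethylamino)ethyl)amino on the carbonyl carbon gives an at least 57-fold lower number from compound 2 to compound 4 (1.75 log units; beyond the scatter), though this step starts from a limit and not a number, the one reached by compound 2: the limit of > 50000 nM in this assay, at which 1 of the 4 values shown sits. Compound 4 also links compound 1 to this series through a single change elsewhere in the molecule, 1-hydroxy-2,2-dimethylpropyl in place of (tert-butyl)carbonyl, which gives a 2.6-fold lower number from compound 1 to compound 4 (0.42 log units; beyond the scatter), so the gap to compound 1 can now be tied to that group and not to the amine.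

The compounds shown leave open how far this insensitivity extends, for instance to an unsubstituted primary amine, a pyrrolidine or a morpholine in place of dimethylamino. They also leave open whether a longer chain carrying the amine would keep these numbers, and whether a carboxylic acid in place of the ester of compound 2 would change its standing.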